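This account rests on a few compounds, and the source may have more. Where it says the series, first, only, none or still open, it means among the compounds named here.

Compound 1 `CN(C)S(=O)(=O)c1ccccc1Nc1cc(-c2ccc3ccn(C)c3c2)c2nccnc2c1` gives 7670 nM in an assay on lysate for inhibition of 6-phosphofructo-2-kinase/fructose-2,6-bisphosphatase 3 (Homo sapiens), with stated times of 0.5 min and 45 min; a lower number here means a stronger inhibitor, a higher number a weaker inhibitor. For compound 2 `Cn1ccc2ccc(-c3cc(Nc4ccccc4S(=O)(=O)Nc4cncnc4)cc4nccnc34)cc21` this assay reports only a limit, > 100000 nM. Among the measured compounds shown here, the single measured step, an at least 13-fold higher number from compound 1 to compound 2 (1.11 log units; beyond the scatter), ends at the limit of > 100000 nM in this assay, at which 1 of the 2 values shown sits, so its true size is unknown. Compound 3 `CN(Cc1cncnc1)S(=O)(=O)c1ccccc1Nc1cc(-c2ccc3ccn(C)c3c2)c2nccnc2c1` carries methyl((pyrimidin-5-yl)methyl)amino in place of (pyrimidin-5-yl)amino on a sulfonyl sulfur. The entering group, like the dimethylamino of compound 1, bears a methyl on nitrogen while keeping the pyrimidinyl of compound 2, so a partial move back toward the number of compound 1 is expected, with a real chance the limit is reached again. Compound 3 is therefore estimated at 40000 nM, between 8000 nM and 150000 nM, an expected step of an at least 2.5-fold lower number from compound 2 to compound 3 (0.39 log units; beyond the scatter).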

Compound 3, half-maximal inhibitory concentration: > 100000 nM
Compound 3: no number, only a limit (the forecaster's own chance of this, stated with the estimate: 40%); at least 2.5-fold (0.39 log units) between middle value and limit.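

In this assay compound 3 gives only a limit, > 100000 nM. Pyrimidin-5-yl in place of hydrogen on the saturated chain carbon gives an at least 13-fold higher number from compound 1 to compound 3 (1.11 log units; beyond the scatter), so keeping a methyl on the sulfonamide nitrogen, with no hydrogen-bond donor in the group, does not preserve the value of compound 1 once this ring is present. The step linking compound 2 and compound 3 cannot be read, because both values are limits: the limit of > 100000 nM in this assay, at which 2 of the 3 values shown sit.

Going by these compounds, how far either compound lies past the limit stays open. Also open, on these data alone, is whether ethyl or a morpholine ring on the sulfonyl sulfur would stay close to compound 1.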